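This account rests on a few compounds, and the source may have more. Where it says the series, first, only, none or still open, it means among the compounds named here.

In a functional assay on GOTO cells (Homo sapiens) for cytotoxicity, read by MTT assay, with a stated time of 3 days (a lower number here means a stronger inhibitor, a higher number a weaker inhibitor), two compounds that share one core have been measured so far. Compound 1 `N#Cc1c(-c2ccccc2)nc(SCc2nc3ccccc3[nH]2)nc1N1CCNCC1` gives 3.7 nM, and compound 2 `CN1CCN(c2nc(SCc3nc4ccccc4[nH]3)nc(-c3ccccc3)c2C#N)CC1` gives 3.37 nM, which places the two level with each other within the scatter. The next compound to be measured is compound 3 `N#Cc1c(-c2ccccc2)nc(SCc2nc3ccccc3[nH]2)nc1N1CCN(S(=O)(=O)c2ccccc2)CC1`. It carries phenylsulfonyl in place of methyl on an amine nitrogen in a ring, and the counted difference is this: phenylsulfonyl in place of methyl on an amine nitrogen in a ring. Among the compounds with values here, only one measured step bears on this change, and it lies at the same ring nitrogen: a 1.1-fold lower number from compound 1 to compound 2 (0.04 log units; within the scatter). That step swaps hydrogen for methyl, so it shows that this nitrogen tolerates a change of one carbon, but it says little about a group as large as phenylsulfonyl. Within the data shown here, no compound with an aromatic ring or a sulfonyl group at this nitrogen has been measured. A moderate move toward a higher number in this assay is therefore expected, though a result within the scatter remains possible. The step is estimated as a 3.0-fold higher number from compound 2 to compound 3 (0.47 log units; beyond the scatter). For compound 3 the expected value is 10 nM, with an estimated range from 2 nM to 50 nM.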

Compound 3, half-maximal inhibitory concentration: 5.81 nM
Compound 3: middle estimate off by 1.7-fold (0.24 log units), on the high side; measured number inside the range.
By their numbers in this assay, from the lowest: compounds 2, 1 and 3 (each within the scatter of the next).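

In this assay, the amine nitrogen in the six-membered non-aromatic ring now proves to accept far more than the single carbon of the earlier change: phenylsulfonyl, with its nine heavy atoms, one six-membered aromatic ring and two hydrogen-bond acceptors, gives a 1.7-fold higher number from compound 2 to compound 3 (0.24 log units; within the scatter) in place of methyl and a 1.6-fold higher number from compound 1 to compound 3 (0.20 log units; within the scatter) in place of hydrogen. Both steps lie within the scatter, so hydrogen, methyl and phenylsulfonyl at this nitrogen cannot be told apart in this cell assay, and the large gain in size and the added aromatic ring leave no readable mark on the number. No measurement at hand explains why this position shows so little response.

The compounds shown leave open whether a benzyl group, an acetyl group or a longer chain ending in a carboxylic acid at this nitrogen would also stay level with these three. They also leave open whether a methoxy or chlorine substituent on the phenyl of the phenylsulfonyl group, or a change elsewhere on the shared core, would move the number beyond the scatter.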